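A Methyl Comes Off the Ring Amine Nitrogen

The source may report more compounds than this note shows. Statements on the series, on what has been measured and on what is new or still open speak of the compounds shown alone.

Of the compounds shown here, two have so far been tested in a functional assay on the whole organism with Mus musculus as the target, with a stated time of 15 min; on this read-out higher numbers stand for an effect only at larger amounts of compound and lower numbers for an effect already at smaller amounts. Compound 1 `Cc1sc2ccccc2c1C1C=CN=CN1C` gives 30 mg/kg in this assay. Compound 2 `CCc1cc(Br)c(C2C=CN=CN2)s1`, built on a different core, gives 30 mg/kg in this assay; compound 1 thus stands level with compound 2, the two values lying within the usual scatter. Compound 3 `Cc1sc2ccccc2c1C1C=CN=CN1` has not yet been measured. It differs from compound 1 in one place: hydrogen in place of methyl on an amine nitrogen in a ring. Going by the values given here, no measured pair shows this exact change, so its size cannot be read directly from the data. Compound 2, however, also carries a hydrogen on its amine nitrogen in a ring, and it sits at the same level as compound 1, which suggests that a compound without this methyl can reach the same dose level. A step of no change at the digits printed from compound 1 to compound 3 (within the scatter) is therefore expected, none beyond the scatter. Compound 3 is estimated to give 30 mg/kg in this assay, with a range from 10 mg/kg to 100 mg/kg.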

Compound 3, minimum effective dose: 3 mg/kg
The estimate for compound 3 lay 10-fold (1.00 log units) above the measured number; measured number below the stated range.
By their numbers in this assay, from the lowest: compound 3; then compounds 1 and 2 (each within the scatter of the next).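

Taking the methyl off the amine nitrogen in the ring matters in this assay: the change gives a 10-fold lower number from compound 1 to compound 3 (1.00 log units; beyond the scatter) and shows that this position is not indifferent to what it carries. The earlier compounds shown here could not show this, as they sit on different cores and differ in more than one place, whereas here a single carbon is the only difference. Nothing measured here explains why hydrogen on this nitrogen goes with an effect at smaller doses.

With only methyl and hydrogen shown at this position, it remains open how an ethyl or an acetyl group on this nitrogen would fare. As far as these compounds go, it is also open whether adding a methyl to the same nitrogen of compound 2 would produce a step of similar size on that different core.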